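This account rests on a few compounds, and the source may have more. Where it says the series, first, only, none or still open, it means among the compounds named here.

Of the compounds shown here, three of one shared core have been tested in an ADME assay on L02 cells (Homo sapiens) for antiproliferative activity, read by MTT assay, with a stated time of 48 h (on this read-out higher numbers stand for weaker inhibition and lower numbers for stronger inhibition), and each sits at a limit. In this assay compound 1 `N#CC1=C(N)Oc2c(c3nc4ccccc4nc3c3ccccc23)C12C(=O)N(Cc1cnnn1-c1ccc(S(N)(=O)=O)cc1)c1ccccc12` reaches only the limit > 50000 nM. Compound 2 `Cc1ccc(Cl)cc1-n1nncc1CN1C(=O)C2(C(C#N)=C(N)Oc3c2c2nc4ccccc4nc2c2ccccc32)c2ccccc21` likewise gives only the limit > 50000 nM. Compound 3 `N#CC1=C(N)Oc2c(N)cc3nc4ccccc4nc3c2C12C(=O)N(Cc1cnnn1-c1ccc(Cl)cc1)c1ccccc12` stands at the same limit, > 50000 nM. Within the data shown here, the one step measured within this set, a step that the two limits leave unreadable from compound 1 to compound 2, is of unreadable size because of the limit of > 50000 nM in this assay, at which 3 of the 3 values shown sit, so the series so far speaks only of weak inhibition across the board.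

Compound 4 `Cc1ccc(-n2nncc2CN2C(=O)C3(C(C#N)=C(N)Oc4c(N)cc5nc6ccccc6nc5c43)c3ccccc32)cc1C` is not yet measured. It differs from compound 3 by 3,4-dimethylphenyl in place of 4-chlorophenyl on an aromatic nitrogen. Among the measured compounds shown here, no measured step exchanges one substituent on that aromatic nitrogen for another at a readable size, so there is nothing to set a direction: the expected step that the limit leaves unreadable from compound 3 to compound 4 is therefore one of no change beyond the scatter. Given that compound 3 gives only the limit > 50000 nM, compound 4 is expected to lie near 60000 nM, within the range 30000 nM to 120000 nM, most likely again reported only as a limit.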

Compound 4, half-maximal inhibitory concentration: > 50000 nM
Compound 4: only a limit was reported; the forecaster's own chance of this, stated with the estimate: 85%; the middle value lies beyond the limit too.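

No new step can be read from compound 3 to compound 4, because both stop at one reported limit: the limit of > 50000 nM in this assay, at which 4 of the 4 values shown sit. The compounds shown leave open how far any of them lies past that limit, and whether changing the group on that aromatic nitrogen alters inhibition in this assay at all.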